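From 2-Chlorophenyl to 3-Aminophenyl on a Shared Core

This account rests on a few compounds, and the source may have more. Where it says the series, first, only, none or still open, it means among the compounds named here.

Compound 1 `COc1cc(C(=O)c2cn(-c3cccc(C)c3)cc2-c2cccc(N)c2)cc(OC)c1OC`: 130 nM
Compound 2 `COc1cc(C(=O)c2cn(-c3cccc(N)c3)cc2-c2cccc(N)c2)cc(OC)c1OC`: 60 nM
Compound 3 `COc1cc(C(=O)c2cn(-c3ccc(F)cc3)cc2-c2ccccc2Cl)cc(OC)c1OC`: 83 nM

In a functional assay on MCF7 cells (Homo sapiens) for cytotoxicity, read by MTT assay, with a stated time of 96 h (on this read-out higher numbers stand for weaker inhibition and lower numbers for stronger inhibition), the value of compound 3 lies within the usual scatter of those of both other compounds. Compound 4 `COc1cc(C(=O)c2cn(-c3ccc(F)cc3)cc2-c2cccc(N)c2)cc(OC)c1OC` has 3-aminophenyl in place of 2-chlorophenyl on an aromatic carbon. Among the compounds with values here, no measured step covers this swap. Within the data shown here, the only measured step, a 2.2-fold lower number from compound 1 to compound 2 (0.34 log units; beyond the scatter), is modest and reflects a different change, amino in place of methyl on an aromatic carbon. Compound 1 and compound 2 both carry 3-aminophenyl and give values close to that of compound 3, so no step beyond the scatter is expected. The expected step is a 1.2-fold lower number from compound 3 to compound 4 (0.07 log units; within the scatter). For compound 4, the estimated value is 70 nM, with an expected range of 25 nM to 200 nM.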

Compound 4, half-maximal inhibitory concentration: 53 nM
Estimate against measurement, compound 4: 1.3-fold (0.12 log units) above; measured number inside the range.
By their numbers in this assay, from the lowest: compounds 4, 2, 3 and 1 (each within the scatter of the next, the first and the last beyond it).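

In this assay, the swap of 2-chlorophenyl for 3-aminophenyl gives a 1.6-fold lower number from compound 3 to compound 4 (0.19 log units; within the scatter) and so leaves no difference that can be told from the scatter at this position on the shared core. On the ring nitrogen, 4-fluorophenyl in place of 3-aminophenyl gives a 1.1-fold lower number from compound 2 to compound 4 (0.05 log units; within the scatter) and 4-fluorophenyl in place of 3-methylphenyl gives a 2.5-fold lower number from compound 1 to compound 4 (0.39 log units; beyond the scatter), so only the second swap stands clear of the scatter. Nothing available explains these steps. Still open, going by these compounds, is how a phenyl ring carrying a carboxylic acid or a longer amine chain would behave at the position of the 3-aminophenyl group.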